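Replacing the piperidine by phenyl on a sulfonamide

This account rests on a few compounds, and the source may have more. Where it says the series, first, only, none or still open, it means among the compounds named here.

Measured compounds:
- compound 1 `O=C(Nc1ccc(S(=O)(=O)N2CCC(Cl)CC2)cc1)c1ccc([N+](=O)[O-])o1`: 800 nM
- compound 2 `CC1(C)CCN(S(=O)(=O)c2ccc(NC(=O)c3ccc([N+](=O)[O-])o3)cc2)CC1`: 600 nM
- compound 3 `CC(C)(C)C1CCN(S(=O)(=O)c2ccc(NC(=O)c3ccc([N+](=O)[O-])o3)cc2)CC1`: 700 nM

All three compounds share one core and differ only in the group on the sulfonyl sulfur. In an assay on CHO-K1 cells for activation of DNA damage-inducible transcript 3 protein (Homo sapiens), read by a luciferase reporter (on this read-out higher numbers stand for an effect only at larger amounts of compound and lower numbers for an effect already at smaller amounts), compound 3 gives 700 nM, the second highest of the three numbers; its nearest neighbour is compound 1 and the furthest is compound 2, and both gaps lie within the scatter. The three steps among the measured compounds, a 1.3-fold lower number from compound 1 to compound 2 (0.12 log units; within the scatter), a 1.1-fold lower number from compound 1 to compound 3 (0.06 log units; within the scatter) and a 1.2-fold higher number from compound 2 to compound 3 (0.07 log units; within the scatter), are all within the scatter, so changing the substituent on the saturated ring left the read-out essentially unchanged.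

Compound 4 `O=C(Nc1ccc(S(=O)(=O)c2ccccc2)cc1)c1ccc([N+](=O)[O-])o1` is not yet measured. It differs from compound 3 as follows: phenyl in place of 4-(tert-butyl)piperidin-1-yl on a sulfonyl sulfur. Among the compounds with values here, none of the measured steps removes the saturated ring itself, so no measured step bears directly on this change; they only show that the sulfonyl substituent tolerated small variation. The expectation is therefore a step of modest size, a 1.3-fold higher number from compound 3 to compound 4 (0.11 log units; within the scatter), with wide uncertainty. Compound 4 is estimated at 900 nM, within a range of 300 nM to 3000 nM.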

Compound 4, concentration for half-maximal activity: 1100 nM
Compound 4: the middle estimate sits 1.2-fold (0.09 log units) below what was measured; measured number inside the range.
By their numbers in this assay, from the lowest: compounds 2, 3, 1 and 4 (each within the scatter of the next).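

In this assay, the saturated ring on the sulfonyl sulfur can be replaced outright by phenyl, giving a 1.6-fold higher number from compound 3 to compound 4 (0.20 log units; within the scatter), a 1.8-fold higher number from compound 2 to compound 4 (0.26 log units; within the scatter) and a 1.4-fold higher number from compound 1 to compound 4 (0.14 log units; within the scatter). The earlier compounds shown here varied only the substituent on the piperidine, whereas these steps exchange the whole ring, with its nitrogen, for an aromatic ring of carbon only, and all three still lie within the scatter. Nothing shown explains why this exchange leaves the read-out so little altered.

As far as these compounds go, it remains open whether a phenyl bearing a carboxylic acid or an amine, or a morpholine ring on the sulfonyl sulfur, would also stay within the scatter. From the compounds shown here alone, the rest of the shared core is the same in all four compounds, so the effect of exchanging its nitro group for a nitrile also remains unknown.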